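The source may report more compounds than this note shows. Statements on the series, on what has been measured and on what is new or still open speak of the compounds shown alone.

Measured so far:
- Compound 1, `Clc1ccc(Sc2c(-c3ccc(Br)cc3)[nH]c3ccccc23)cc1`: 35000 nM
- Compound 2, `COc1ccc2[nH]c(-c3ccc(Cl)cc3)c(Oc3ccc(Cl)cc3)c2c1`: 31000 nM
- Compound 3, `CCOC(=O)C1CCN(C(=S)Sc2c(-c3ccc(Br)cc3)n(C)c3ccccc23)CC1`: 50000 nM

All three were tested in a functional assay on B16-F10 cells (Mus musculus) for inhibition, read by MTT assay, with a stated time of 72 h; a higher number here means a weaker inhibitor of growth, a lower number a stronger inhibitor of growth. Compound 2 stands close to both others: its number and that of compound 1, and likewise that of compound 3, lie within the usual scatter of such measurements, so nothing separates them. Compound 4, `CCOC(=O)c1ccc2[nH]c(-c3ccc(Cl)cc3)c(Oc3ccc(Cl)cc3)c2c1`, has not been measured. It differs from compound 2 in one place: ethoxycarbonyl in place of methoxy on an aromatic carbon. Among the compounds with values here, no measured pair shows what such a swap does here, so the expectation rests on compound 2 alone. The step from compound 2 to compound 4 is expected to be a 1.0-fold lower number from compound 2 to compound 4 (0.01 log units; within the scatter), with no direction beyond the scatter. Compound 4 is therefore estimated at 30000 nM, between 8000 nM and 120000 nM.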

Compound 4, concentration for 50% growth inhibition: 20000 nM
Beside the measured number, compound 4's estimate is 1.5-fold (0.18 log units) above it; measured number inside the range.
By their numbers in this assay, from the lowest: compounds 4, 2, 1 and 3 (each within the scatter of the next, the first and the last beyond it).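

In this assay, putting ethoxycarbonyl in place of methoxy on this aromatic carbon gives a 1.6-fold lower number from compound 2 to compound 4 (0.19 log units; within the scatter) and so stays within the scatter. Within the data shown here, this position therefore accepts a group with more heavy atoms and an added carbonyl without a clear change in the number, something the earlier compounds could not show. No measured evidence here bears on why this is so. As far as these compounds go, whether a carboxylic acid or an amine on the same carbon would move the number beyond the scatter remains open. So does whether a smaller group, such as fluorine, would.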